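Aryl amine replacement on the shared core, compound 4

This account rests on a few compounds, and the source may have more. Where it says the series, first, only, none or still open, it means among the compounds named here.

Measured so far in an assay on cells (Epithelial cell) with Cystic fibrosis transmembrane conductance regulator variant F508del (Homo sapiens) as the target, read by fluorescence, with a stated time of 20 h; a lower number here means a stronger inhibitor, a higher number a weaker inhibitor:
compound 1 `COc1ccc(Cl)cc1Nc1nc2c(s1)CCCCc1nc(NC(=O)C3CC3)sc1-2`: 4500 nM
compound 2 `COC(=O)CCC(=O)Nc1nc2c(s1)-c1nc(Nc3cc(Cl)ccc3OC)sc1CCCC2`: 8300 nM
compound 3 `CN(C)c1ccc(Cl)cc1Nc1nc2c(s1)CCCCc1nc(NC(=O)C(C)(C)C)sc1-2`: 2100 nM

Compound 3 stands lowest of the three numbers; its separation from compound 1 and from compound 2 is beyond the scatter, so within this set it is the strongest inhibitor. Going by the values given here, the one single-point step on record, a 1.8-fold higher number from compound 1 to compound 2 (0.27 log units; within the scatter), concerns the group on the carbonyl carbon and lies within the scatter.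

Compound 4 `COc1ccc([N+](=O)[O-])cc1Nc1nc2c(s1)CCCCc1nc(NC(=O)C(C)(C)C)sc1-2` differs from compound 3 in one place: 2-methoxy-5-nitrophenyl in place of 5-chloro-2-(dimethylamino)phenyl on a nitrogen on an aromatic ring. Among the compounds with values here, no measured step touches the aryl group on that nitrogen. Within the data shown here, compound 1 and compound 3 differ there as well, but also on the carbonyl carbon, so their two values show only that the pair with dimethylamino and chloro sits somewhat lower than the pair with methoxy and chloro. The carbonyl-side change of compound 1 to compound 2 gives no guidance on an aryl change.

With nothing measured bearing directly on this swap, a step of a 1.7-fold higher number from compound 3 to compound 4 (0.22 log units; within the scatter) is expected, most likely a mild weakening at the edge of the scatter. Compound 4 is estimated at 3500 nM, in the range 1400 nM to 9000 nM.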

Compound 4, half-maximal inhibitory concentration: 900 nM
For compound 4 the middle estimate is 3.9-fold (0.59 log units) above the measured one, and the stated range ends above it.
By their numbers in this assay, from the lowest: compound 4; then compound 3; then compounds 1 and 2 (each within the scatter of the next).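

In this assay, going by these compounds alone, the step of a 2.3-fold lower number from compound 3 to compound 4 (0.37 log units; beyond the scatter) is the first single-place change at the aryl group on this nitrogen, and it lies beyond the scatter, so this site responds to substitution, unlike the carbonyl-carbon change in the step of a 1.8-fold higher number from compound 1 to compound 2 (0.27 log units; within the scatter), which lies within it. The ring in compound 4 carries neither the chlorine nor the dimethylamino group present in compound 3, so in this series neither group is required for a number as low as that of compound 4 at 900 nM on this carbonyl side. Nothing at hand accounts for the direction or the size of this step.

Because the swap changes both ring substituents at once, the compounds shown leave open which of the two carries the step, and how a nitrile, a trifluoromethyl group or a carboxylic acid would read in place of the nitro group. From the compounds shown here alone, whether the same aryl swap holds with cyclopropyl or 2-(methoxycarbonyl)ethyl on the carbonyl carbon also remains open.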